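Swapping a thiazole for a thiophenylmethyl on the amine

The compounds below may be only part of what the source reports. "The series", "measured", "known", "first", "only" and "open" are said of these compounds alone.

Compound 1 `CCOC(=O)NCCNc1nc(C)c(-c2nc3ccccc3s2)c(N[C@@H]2C[C@H](CO)[C@@H](O)[C@H]2O)n1`: in an ADME assay on cells (Homo sapiens) for cytotoxicity, read by polymerase chain reaction, with a stated time of 3 days (on this read-out lower numbers stand for higher toxicity in this test and higher numbers for lower toxicity in this test), compound 1 gives 12000 nM.
Compound 2 `Cc1nc(NCCCC(F)(F)F)nc(N[C@@H]2C[C@H](CO)[C@@H](O)[C@H]2O)c1-c1nc2ccccc2s1`: in this assay compound 2 gives 3000 nM.
Compound 3 `Cc1nc(Nc2nccs2)nc(N[C@@H]2C[C@H](CO)[C@@H](O)[C@H]2O)c1-c1nc2ccccc2s1`: in this assay compound 3 gives 15000 nM.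

Compound 3 has the highest number of the three, meaning the least toxicity in this test, although its gap to compound 1 lies within the scatter, so the two cannot be ranked against each other. Only compound 2 stands clearly apart, as a 5.0-fold higher number from compound 2 to compound 3 (0.70 log units; beyond the scatter) shows. Compound 4 `Cc1nc(NCc2cccs2)nc(N[C@@H]2C[C@H](CO)[C@@H](O)[C@H]2O)c1-c1nc2ccccc2s1` differs from compound 3 in a single place: (thiophen-2-yl)methyl in place of 1,3-thiazol-2-yl on a nitrogen on an aromatic ring. Among the compounds with values here, two measured steps bear on this change. The step of a 5.0-fold higher number from compound 2 to compound 3 (0.70 log units; beyond the scatter), where 4,4,4-trifluorobutyl gave way to 1,3-thiazol-2-yl, raised the number modestly, while a 1.3-fold higher number from compound 1 to compound 3 (0.10 log units; within the scatter), where 2-((ethoxycarbonyl)amino)ethyl gave way to the same group, stayed within the scatter. Compound 4 keeps an aromatic ring on that nitrogen but reaches it through a methyl link, so it resembles both compound 3 and the chain-bearing compounds. The expectation for compound 4 is therefore a modestly lower number, a 2.1-fold lower number from compound 3 to compound 4 (0.33 log units; beyond the scatter), in this assay. Compound 4 is estimated at 7000 nM, with a range from 2500 nM to 20000 nM.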

Compound 4, half-maximal cytotoxic concentration: 6000 nM
For compound 4 the middle estimate is 1.2-fold (0.07 log units) above the measured one; low and high end bracket the measured number.
By their numbers in this assay, from the lowest: compounds 2, 4, 1 and 3 (each within the scatter of the next, the first and the last beyond it).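

In this assay, moving from 1,3-thiazol-2-yl to (thiophen-2-yl)methyl on this nitrogen gives a 2.5-fold lower number from compound 3 to compound 4 (0.40 log units; beyond the scatter) and lies beyond the scatter, so keeping a five-membered aromatic ring here does not by itself keep the number at the level of compound 3. The chain-bearing compounds differ from each other by a 4.0-fold lower number from compound 1 to compound 2 (0.60 log units; beyond the scatter) yet neither can be separated from compound 4: the printed steps are a 2.0-fold higher number from compound 2 to compound 4 (0.30 log units; within the scatter) and a 2.0-fold lower number from compound 1 to compound 4 (0.30 log units; within the scatter) and both lie within the scatter, so this position tolerates quite different groups with only modest shifts across these four compounds. No measurements on hand explain why the number moves with this change.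

The swap alters two things at once, the methyl link and the ring itself, so the compounds shown cannot say which of them matters. Thiophen-2-yl attached directly to the nitrogen, or (1,3-thiazol-2-yl)methyl, would pull the two apart, and a plain benzyl group would show whether either sulfur-containing ring is needed at all.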